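A few compounds are considered here, and "the series" means these few. Any claim that something is new, unique, unknown or untested is made for them only; others in the source may bear on it.

Series notes. In an assay on CHO cells for displacement of a labelled ligand from adenosine receptor A1 (Homo sapiens), read by scintillation counting, with a stated time of 3 h (on this read-out lower numbers stand for stronger inhibition and higher numbers for weaker inhibition), compound 2 `CCn1c(-c2ccccc2)nc2c(NC3CCCCC3)ncnc21` gives 10 nM, the lowest of the three numbers; compound 1 `Cn1c(-c2ccc(O)cc2)nc2c(NC3CCCC3)ncnc21` gives 17 nM, within the scatter of compound 2, and compound 3 `Cc1ccccc1-c1nc2c(NC3CCCC3)ncnc2n1C` gives 55 nM, beyond it. Going by the values given here, the only measured step, a 3.2-fold higher number from compound 1 to compound 3 (0.51 log units; beyond the scatter), concerns the aryl group on an aromatic carbon and does not bear on the change followed here. Compound 4 `CCn1c(-c2ccccc2)nc2c(N)ncnc21` differs from compound 2 by hydrogen in place of cyclohexyl on a nitrogen on an aromatic ring. Among the compounds with values here, no measured pair shows this nitrogen with and without its cyclohexyl, so nothing anchors the size of the step. A marked weakening is nonetheless expected, and compound 4 is expected to show a 50-fold higher number from compound 2 to compound 4 (1.70 log units; beyond the scatter) in this assay. The estimate for compound 4 is 500 nM, with a range of 100 nM to 3000 nM.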

Compound 4, inhibition constant: 31 nM
Beside the measured number, compound 4's estimate is 16-fold (1.21 log units) above it; the whole stated range lies above it.
By their numbers in this assay, from the lowest: compounds 2, 1, 4 and 3 (each within the scatter of the next, the first and the last beyond it).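

Going by these compounds alone, with the cyclohexylamino to amino change read directly for the first time, a 3.1-fold higher number from compound 2 to compound 4 (0.49 log units; beyond the scatter) in this assay is a modest step, though one beyond the scatter. The cyclohexyl therefore adds to the affinity on this core, but compound 4 shows that the unsubstituted amino group alone retains a nanomolar value. No measurement at hand accounts for the size of this step. Open, going by these compounds, is how intermediate groups on this nitrogen, such as methyl or a propyl chain, would compare, and whether a larger group such as benzyl would lower the number further.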